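The source may hold more compounds than are shown below. What is called first, only, known or untested is meant among the compounds shown, and "the series" means these compounds.

Compound 1 `Cc1ccnc(/C(N)=N/NC(=S)N2CCSCC2)c1`: 78.3%
Compound 2 `N/C(=N\NC(=S)N1CCSCC1)c1ccccn1`: 80.6%

In a functional assay on HeLa cells (Homo sapiens) for cytotoxicity, read by MTT assay, with a stated time of 72 h, tested at 30 uM (on this read-out lower numbers stand for less inhibition of growth and higher numbers for more inhibition of growth at the one concentration tested), compound 2 gives 80.6%, the higher of the two numbers, although a number 2.3 percentage points higher from compound 1 to compound 2 (within the scatter) stays within the scatter. Compound 3 `N/C(=N\NC(=S)N1CCCC1)c1ccccn1` differs from compound 2 in one place: pyrrolidin-1-yl in place of thiomorpholin-4-yl on a thiocarbonyl carbon. Among the measured compounds shown here, no measured step touches this part of the molecule; the only step known, a number 2.3 percentage points higher from compound 1 to compound 2 (within the scatter), concerns a methyl on an aromatic carbon elsewhere. With nothing to point either way, no shift beyond the scatter is expected in this assay. Compound 3 is therefore estimated at 78%, between 60% and 92%. That expected step is a number 2.6 percentage points lower from compound 2 to compound 3 (within the scatter).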

Compound 3, percent growth inhibition at one concentration: 84.5%
Estimate against measurement, compound 3: 6.5 percentage points below, and the stated range covers the measured number.
By their numbers in this assay, from the lowest: compounds 1, 2 and 3 (each within the scatter of the next).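

In this assay, among the compounds shown here, the step of a number 3.9 percentage points higher from compound 2 to compound 3 (within the scatter) gives the first view of the group on the thiocarbonyl carbon. Within this pair, a five-membered ring without sulfur stands in for a six-membered ring with sulfur, and growth inhibition stays within the scatter, so the ring sulfur is not required to keep this level. No available evidence explains this result. Still open, from the compounds shown here alone, is how an open-chain group such as dimethylamino, or a morpholin-4-yl ring, would behave on the thiocarbonyl carbon.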